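The source may report more compounds than this note shows. Statements on the series, on what has been measured and on what is new or still open speak of the compounds shown alone.

Compound 1 `C[C@H](c1ccc(C(=O)NCCC(=O)O)cc1)N1C(=O)C(c2ccccc2F)=N[C@]12CC[C@@H](C(C)(C)C)CC2` was tested in an assay on membranes from liver for displacement of a labelled ligand from Glucagon receptor (Mus musculus), read by scintillation counting, with a stated time of 60 min; on this read-out lower numbers stand for stronger inhibition and higher numbers for weaker inhibition. In this assay compound 1 reaches only the limit of > 10000 nM, so no number is known for it. Compound 2 `CC(C)(C)[C@H]1CC[C@]2(CC1)N=C(c1ccc(Cl)cc1)C(=O)N2Cc1ccc(C(=O)NCCC(=O)O)cc1` likewise returns only a limit in this assay, > 10000 nM. Compound 3 `CC(C)(C)CC[C@H](c1ccc(C(=O)NCc2nn[nH]n2)cc1)N1C(=O)C(c2cccc(C(F)(F)F)c2)=N[C@]12CC[C@@H](C(C)(C)C)CC2`, which carries a different group on the carbon with a double bond to nitrogen and a different side chain, gives 140 nM in this assay. Of the three values shown, compound 1 stands at the limit alongside compound 2 (the limit of > 10000 nM in this assay, at which 2 of the 3 values shown sit), while compound 3 alone gives a measurable number.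

The step to compound 4 `C[C@H](c1ccc(C(=O)NCCC(=O)O)cc1)N1C(=O)C(c2ccc(F)cc2)=N[C@]12CC[C@@H](C(C)(C)C)CC2` changes one place in the core: 4-fluorophenyl in place of 2-fluorophenyl on a carbon with a double bond to nitrogen. Among the compounds with values here, no pair of measured compounds differs in one place, so no measured step guides the size of this change. Because compound 1 sits at the limit of > 10000 nM, the step in this assay cannot be sized from above, and the expectation for compound 4 is that it will again fall at or near that limit rather than move beyond the scatter. The estimated step from compound 1 to compound 4 is a step that the limit leaves unreadable from compound 1 to compound 4. Compound 4 is therefore expected to give about 15000 nM in this assay, within a range from 3000 nM to 60000 nM.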

Compound 4, half-maximal inhibitory concentration: 2500 nM
Beside the measured number, compound 4's estimate is 6.0-fold (0.78 log units) above it; the measured number lies below the stated range.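

Setting 4-fluorophenyl in place of 2-fluorophenyl on the carbon with a double bond to nitrogen gives an at least 4.0-fold lower number from compound 1 to compound 4 (0.60 log units; beyond the scatter) in this assay, although both groups have the same atoms and the same counts of donors and acceptors. Within the data shown here, this is the first comparison between compounds that differ in one place, and it shows that this position responds to the place of the fluorine on the phenyl ring, and that the core and carboxylic acid side chain of compound 1 do not rule out a measurable number in this assay. The full size of the step cannot be read, since compound 1 gives only a limit: the limit of > 10000 nM in this assay, at which 2 of the 4 values shown sit.

The compounds shown leave open how a plain phenyl, a pyridyl or a methoxyphenyl group would behave at this position on the same core. They also leave open whether the step would hold with an amine in place of the carboxylic acid at the end of the side chain.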